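Swapping 1-phenylethyl for cyclobutyl on the amide

The source may hold more compounds than are shown below. What is called first, only, known or untested is meant among the compounds shown, and "the series" means these compounds.

Values in a functional assay on KETR3 cells (Homo sapiens) for inhibition, read by MTT assay, with a stated time of 120 h; a higher number here means a weaker inhibitor, a lower number a stronger inhibitor:
Compound 1 `O=C(/C=C/c1ccc(NC(=O)Nc2ccc(Cl)c(C(F)(F)F)c2)cc1)NC1CCC1`: 17300 nM
Compound 2 `CC(NC(=O)CCc1ccc(NC(=O)Nc2ccc(Cl)c(C(F)(F)F)c2)cc1)c1ccccc1`: > 50000 nM (a limit, not a number)

Compound 2 has no exact value in this assay: its result, > 50000 nM, is only a limit. As far as these compounds go, it therefore marks the weak end of what the test can report, and the true figure for this compound remains unknown.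

Compound 3 `O=C(CCc1ccc(NC(=O)Nc2ccc(Cl)c(C(F)(F)F)c2)cc1)NC1CCC1` keeps the chain and the rest of compound 2 and changes one group. It has cyclobutyl in place of 1-phenylethyl on an amide-type nitrogen.

Compound 1 also carries cyclobutyl on an amide-type nitrogen and gives 17300 nM, although its chain is not the same as that of compound 3. This measured number is the main reason to expect a result that can be read as a number, in the same weak range.

The expected change is an at least 1.7-fold lower number from compound 2 to compound 3 (0.25 log units; that floor lies within the scatter), a modest move toward stronger inhibition. Its size is rough, as the starting point is only a limit.

For compound 3, the estimated half-maximal inhibitory concentration is 28000 nM, with an expected range of 12000 nM to 50000 nM.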

Compound 3, half-maximal inhibitory concentration: > 50000 nM
Compound 3: no number, only a limit; the forecaster's own chance of this, stated with the estimate: 35%; middle value at least 1.7-fold (0.25 log units) from the limit.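

In this assay, cyclobutyl on the amide-type nitrogen is not enough on its own to give a readable number, so the measurable value of compound 1 cannot be credited to that group alone. The chain matters as well: 2-(cyclobutylcarbamoyl)ethyl in place of 2-(cyclobutylcarbamoyl)ethenyl gives an at least 2.8-fold higher number from compound 1 to compound 3 (0.46 log units; beyond the scatter), so with cyclobutyl held constant, the ethenyl chain goes with the stronger result. The step between the two amide groups cannot be read, because compound 2 and compound 3 both rest on the same limit: the limit of > 50000 nM in this assay, at which 2 of the 3 values shown sit.

As far as these compounds go, the true values of compound 2 and compound 3 therefore stay unknown, and so does any ranking of 1-phenylethyl against cyclobutyl on the saturated chain. The compounds shown also leave open whether 1-phenylethyl on the ethenyl chain, or another group on that amide-type nitrogen such as cyclopropyl or a hydroxyethyl chain, would give a number different from that of compound 1.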